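The source may hold more compounds than are shown below. What is called first, only, known or untested is meant among the compounds shown, and "the series" means these compounds.

Compound 1 `CC1CCCC1C(=O)CN1C(=O)N(CC(=O)Nc2cccc(C(=O)O)c2)N=C(C2CCCCC2)c2ccccc21` is tested in an assay on CHO-K1 cells for displacement of a labelled ligand from Cholecystokinin receptor type A (Homo sapiens) (a lower number here means a stronger inhibitor, a higher number a weaker inhibitor), and there compound 1 gives 3980 nM. Compound 3 `CC(C)(C)C(=O)CN1C(=O)N(CC(=O)Nc2cccc(-c3nn[nH]n3)c2)N=C(C2CCCCC2)c2ccccc21` gives 1740 nM, the lower of the two numbers measured, so compound 1 stands highest of them. Compound 2 `CC(C)(C)C(=O)CN1C(=O)N(CC(=O)Nc2cccc(CCC(=O)O)c2)N=C(C2CCCCC2)c2ccccc21` reaches only a limit of the assay the limit of > 10000 nM in this assay, at which 1 of the 3 values shown sits, and is recorded as > 10000 nM, not as a number. Among the measured compounds shown here, the one measured step, an at least 5.7-fold lower number from compound 2 to compound 3 (0.75 log units; beyond the scatter), concerns the group on the aromatic carbon. Compound 4 `O=C(CN1N=C(C2CCCCC2)c2ccccc2N(CC(=O)C2CCCCC2)C1=O)Nc1cccc(C(=O)O)c1` differs from compound 1 elsewhere: cyclohexyl in place of 2-methylcyclopentyl on a carbonyl carbon. For the measured compounds named here, no measured step touches this side of the shared core, so the change is expected to stay within the usual scatter, a 1.1-fold lower number from compound 1 to compound 4 (0.06 log units; within the scatter). Compound 4 is therefore estimated at 3500 nM, within a range from 1200 nM to 10000 nM.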

Compound 4, inhibition constant: 7940 nM
For compound 4 the middle estimate is 2.3-fold (0.36 log units) below the measured one, and the stated range covers the measured number.
By their numbers in this assay, from the lowest: compound 3; then compounds 1 and 4 (each within the scatter of the next). At a limit, above all of these: compound 2.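

Cyclohexyl in place of 2-methylcyclopentyl on a carbonyl carbon is the first measured change on this side of the shared core, and in this assay it gives a 2.0-fold higher number from compound 1 to compound 4 (0.30 log units; within the scatter). These two carbon-only rings, with the same count of heavy atoms, therefore cannot be told apart in this pair. Nothing shown here bears on why they read alike. Going by these compounds, whether an open chain, a phenyl ring or an amine on this carbonyl carbon would read the same remains open.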